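A Fluorine Added to a Core Without Measurable Activity

The compounds below may be only part of what the source reports. "The series", "measured", "known", "first", "only" and "open" are said of these compounds alone.

Compound 1, `Nc1cc(=O)[nH]c(=O)n1[C@@H]1O[C@H](CO)[C@@H](O)[C@H]1O`: in a functional assay on COLO 205 cells (Homo sapiens) for antiproliferative activity, read by WST assay, with a stated time of 3 days (on this read-out higher numbers stand for weaker inhibition and lower numbers for stronger inhibition), compound 1 gives > 50000 nM, which is a limit of the assay rather than a number.
Compound 2, `COC(=O)c1cc(=O)[nH]c(=O)n1[C@@H]1O[C@H](CO)[C@@H](O)[C@H]1O`: in this assay compound 2 gives > 50000 nM, again a limit of the assay.
Compound 3, `CNc1cc(=O)[nH]c(=O)n1[C@@H]1O[C@H](CO)[C@@H](O)[C@H]1O`: in this assay compound 3 gives > 50000 nM, again a limit of the assay.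

Compound 1 therefore stands only at a limit, with no measured number to place it. The same holds for its two neighbours, as the limit of > 50000 nM in this assay, at which 3 of the 3 values shown sit, shows. The steps a step that the two limits leave unreadable from compound 1 to compound 2, a step that the two limits leave unreadable from compound 1 to compound 3 and a step that the two limits leave unreadable from compound 2 to compound 3 cannot be sized, so none of them gives a readable guide.

Compound 4, `Nc1c(F)c(=O)[nH]c(=O)n1[C@@H]1O[C@H](CO)[C@@H](O)[C@H]1O`, differs from compound 1 in one place: fluoro in place of hydrogen on an aromatic carbon. Among the measured compounds shown here, no measured step bears on this change in a readable way, so no step beyond the scatter in this assay can be expected in either direction; the likeliest outcome is that compound 4 also sits at the limit. Compound 4 is therefore estimated at 60000 nM, with a range from 15000 nM to 200000 nM, which means an expected step that the limit leaves unreadable from compound 1 to compound 4.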

Compound 4, half-maximal inhibitory concentration: 3300 nM
Estimate against measurement, compound 4: 18-fold (1.26 log units) above; the measured number lies below the stated range.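

In this assay, fluoro in place of hydrogen on this aromatic carbon, ortho to the amino group, gives an at least 15-fold lower number from compound 1 to compound 4 (1.18 log units; beyond the scatter), and on this read-out a lower number stands for stronger inhibition. This position therefore responds to the exchange of a single hydrogen for one fluorine, on a core that the three earlier compounds left without a measured number. Compound 4 alone carries a number rather than a limit, which makes this the first step in the set whose direction and size can be read: the limit of > 50000 nM in this assay, at which 3 of the 4 values shown sit.

As far as these compounds go, it stays open whether the gain belongs to fluoro alone or would also come with chloro, bromo or a methyl group on the same carbon. From the compounds shown here alone, it is equally open whether fluoro would act the same way on compound 3, with methylamino in place of amino.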